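The source may report more compounds than this note shows. Statements on the series, on what has been measured and on what is new or still open speak of the compounds shown alone.

Values in a functional assay on HCC 2998 cells (Homo sapiens) for inhibition; on this read-out lower numbers stand for stronger inhibition of growth and higher numbers for weaker inhibition of growth:
- compound 1 `NC(=O)c1cc(Cl)ccc1NC(=O)COc1ccccc1`: 12100 nM
- compound 2 `NC(=O)c1cc(I)ccc1NC(=O)COc1ccccc1`: 2950 nM

Within the data shown here, of these two numbers, the lower belongs to compound 2 at 2950 nM, and it is the better of the pair so far. Next is compound 3 `COc1ccc(NC(=O)COc2ccccc2)c(C(N)=O)c1`, with methoxy in place of iodo on an aromatic carbon. Among the measured compounds shown here, only one measured step bears on this change: a 4.1-fold lower number from compound 1 to compound 2 (0.61 log units; beyond the scatter), a modest step beyond the scatter, with iodo in place of chloro. For the measured compounds named here, no methoxy compound has been measured yet, so this single step is a weak guide. Losing the iodo is expected to give back most of that gain in this assay, so a somewhat smaller step towards a higher number is expected. The expected step is a 2.7-fold higher number from compound 2 to compound 3 (0.43 log units; beyond the scatter). For compound 3 the estimate is 8000 nM, with an expected range of 3000 nM to 22000 nM.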

Compound 3, concentration for 50% growth inhibition: 2340 nM
Estimate against measurement, compound 3: 3.4-fold (0.53 log units) above, and the stated range ends above it.
By their numbers in this assay, from the lowest: compounds 3 and 2 (each within the scatter of the next); then compound 1.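

In this assay, methoxy in place of iodo gives a 1.3-fold lower number from compound 2 to compound 3 (0.10 log units; within the scatter), so at this position, para to a large group, two quite different substituents read alike: a single iodine atom and a methoxy group with its hydrogen-bond acceptor. Methoxy in place of chloro gives a 5.2-fold lower number from compound 1 to compound 3 (0.71 log units; beyond the scatter) in the same direction as the earlier iodo step, so that gain is not tied to iodo, and among the three compounds chloro is the one that stands apart. Nothing at hand explains why compound 1 differs from the other two.

Open, going by these compounds, is whether an amine, a carboxylic acid or a longer alkoxy chain at this position would read with methoxy and iodo or with chloro. Also open, on these data alone, is how the core with plain hydrogen at this position compares with all three.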